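The source may report more compounds than this note shows. Statements on the series, on what has been measured and on what is new or still open speak of the compounds shown alone.

Compounds measured in a functional assay on PANC-1 cells (Homo sapiens) for inhibition, read by MTT assay, with a stated time of 24 h, tested at 10 uM; on this read-out higher numbers stand for more inhibition at the one concentration tested (going by the name of the read-out) and lower numbers for less inhibition:

compound 1, `CC(C)=CCC/C(C)=C/COc1cc(=O)n(CCCO)c2c1CC(CC=C(C)C)C(C)(C)C2`, 18.4%
compound 2, `CC(C)=CCC1Cc2c(OCCCNS(=O)(=O)c3ccc(Br)cc3)cc(=O)n(CCCO)c2CC1(C)C`, 3.7%
compound 3, `CC(C)=CCC/C(C)=C/COc1cc(=O)n(CCCO)c2c1CC(C/C=C(\C)CCC=C(C)C)C(C)(C)C2`, 3.1%

Compound 3 stands lowest of the three numbers in this assay. Its nearest neighbour is compound 2, whose value lies within the scatter of that of compound 3, so no order between these two can be read. Going by the values given here, the furthest is compound 1, and the one step between compounds that differ in a single place runs between them: a number 15.3 percentage points lower from compound 1 to compound 3 (beyond the scatter).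

Compound 4, `CC(C)=CCC/C(C)=C/CC1Cc2c(OCCCOc3ccc(Cl)cc3)cc(=O)n(CCCO)c2CC1(C)C`, differs from compound 3 at another place: 2-(4-chlorophenoxy)ethyl in place of 2,6-dimethylhepta-1,5-dien-1-yl on a saturated chain carbon bound to an oxygen on an aromatic ring.

Among the compounds with values here, no measured step bears on this change. Within the data shown here, the only step known concerns the group on the saturated chain carbon bound to a double-bonded chain carbon, which compound 4 keeps exactly as compound 3 has it. Among the measured compounds shown here, the values of compound 2 and compound 3 show only that two compounds with quite different chains on the ring oxygen both sit low in this assay. With nothing that speaks for a rise, compound 4 is expected to stay close to compound 3, with a step of a number 2.9 percentage points higher from compound 3 to compound 4 (within the scatter) that is not expected to exceed the scatter. Compound 4 is therefore estimated at 6%, in a range from 0% to 20%.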

Compound 4, a percentage reported as inhibition, at one concentration (the size of the read-out at that concentration, not a potency): 0%
For compound 4 the middle estimate is 6 percentage points above the measured one, within the range that was stated.
By their numbers in this assay, from the lowest: compounds 4, 3 and 2 (each within the scatter of the next); then compound 1.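

Going by these compounds alone, the exchange of 2,6-dimethylhepta-1,5-dien-1-yl for 2-(4-chlorophenoxy)ethyl on a saturated chain carbon bound to an oxygen on an aromatic ring gives the only step known at this place in this assay: a number 3.1 percentage points lower from compound 3 to compound 4 (within the scatter). It shows that a group with no ring and two double bonds outside aromatic rings and a group with one six-membered aromatic ring and one hydrogen-bond acceptor cannot be told apart here, with compound 3 at 3.1% and compound 4 at 0%, so both numbers sit at the low end and this pair reveals no gain from the change. Nothing at hand explains this result.

As far as these compounds go, it remains open whether a chain ending in an amine or a carboxylic acid in place of the 4-chlorophenoxy end would give a higher number at this place. Also open, from the compounds shown here alone, is whether 2-(4-chlorophenoxy)ethyl would give a similarly low number on the core of compound 1, which carries 3-methylbut-2-en-1-yl at the other place and gives 18.4%.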